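From 4-chlorophenyl to naphthalen-1-yl on the amide-type nitrogen

The compounds below may be only part of what the source reports. "The series", "measured", "known", "first", "only" and "open" are said of these compounds alone.

Measured in a functional assay on K562 cells (Homo sapiens) for antiproliferative activity, read by MTT assay, with a stated time of 48 h; a higher number here means a weaker inhibitor, a lower number a stronger inhibitor:
Compound 1 (`Cn1cc(C2=C(c3nn(CCCN4CCCCC4)c4ncccc34)C(=O)N(c3ccccc3)C2=O)c2ccccc21`) gives 3790 nM
Compound 2 (`Cn1cc(C2=C(c3nn(CCCN4CCCCC4)c4ncccc34)C(=O)N(c3ccc(Cl)cc3)C2=O)c2ccccc21`) gives 1800 nM

In this assay compound 2 stands lowest of the two at 1800 nM and is the better of the pair. Compound 3 (`Cn1cc(C2=C(c3nn(CCCN4CCCCC4)c4ncccc34)C(=O)N(c3cccc4ccccc34)C2=O)c2ccccc21`) has naphthalen-1-yl in place of 4-chlorophenyl on an amide-type nitrogen in a ring. Within the data shown here, the one measured step bearing on this is chloro in place of hydrogen on an aromatic carbon, which gave a 2.1-fold lower number from compound 1 to compound 2 (0.32 log units; beyond the scatter) and was modest. Among the measured compounds shown here, no measured compound shows a naphthalen-1-yl group, so the direction stays open, and a step of similar or smaller size is expected. The estimated step is a 1.1-fold lower number from compound 2 to compound 3 (0.05 log units; within the scatter) and would not clearly exceed the scatter. For compound 3 the expected value is 1600 nM with a range of 550 nM to 4500 nM as estimated here.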

Compound 3, half-maximal inhibitory concentration: 3180 nM
Compound 3: middle estimate off by 2.0-fold (0.30 log units), on the low side; measured number inside the range.
By their numbers in this assay, from the lowest: compounds 2, 3 and 1 (each within the scatter of the next, the first and the last beyond it).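

In this assay the amide-type nitrogen in a ring carries naphthalen-1-yl, with its two six-membered aromatic rings, with no step beyond the scatter from either single-ring group: a 1.8-fold higher number from compound 2 to compound 3 (0.25 log units; within the scatter) and a 1.2-fold lower number from compound 1 to compound 3 (0.08 log units; within the scatter). Compound 3 thus cannot be told apart from compound 2 or compound 1, even though those two differ beyond the scatter. Nothing measured here explains these steps. Still open, going by these compounds, is how a benzyl group, or a longer chain ending in an amine, would read on that nitrogen.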